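Amine swap on the core of compound 1

The source may hold more compounds than are shown below. What is called first, only, known or untested is meant among the compounds shown, and "the series" means these compounds.

Compound 1 `Cc1cc(N(C)C)nc2ccc(NC(=O)c3ccc(Cl)c(Cl)c3)cc12` carries a dimethylamino group on its core. Going by the values given here, in a functional assay on SK-BR-3 cells (Homo sapiens) for antiproliferative activity, read by MTT assay, with a stated time of 72 h (a lower number here means a stronger inhibitor, a higher number a weaker inhibitor), compound 1 reaches only a limit, > 50000 nM, so no number is known for it; the limit of > 50000 nM in this assay, at which 1 of the 3 values shown sits, notes that this is the sole limit among the values to hand. Compound 2 `CCN1CCN(c2cc(C)c3cc(NC(=O)c4ccc(F)cc4)ccc3n2)CC1` gives 19800 nM in this assay. Among the compounds with values here, compound 3 `CCN1CCN(c2cc(C)c3cc(NC(=O)c4cc5ccccc5[nH]4)ccc3n2)CC1` gives 2550 nM in this assay, and the single measured step, a 7.8-fold lower number from compound 2 to compound 3 (0.89 log units; beyond the scatter), concerns the group on the carbonyl carbon and not the amine. Compound 4 `Cc1cc(N2CCCC2)nc2ccc(NC(=O)c3ccc(Cl)c(Cl)c3)cc12` differs from compound 1 by pyrrolidin-1-yl in place of dimethylamino on an aromatic carbon. Within the data shown here, no measured step touches this part of the core, and compounds 2 and 3 carry both a different amine and a different group on the carbonyl carbon, so they give no direct read on the change. The expectation for compound 4 is therefore no step beyond the scatter, a number no higher from compound 1 to compound 4 (the limit leaves the size open), with the direction open. Compound 4 is estimated at 50000 nM in this assay, within a range from 15000 nM to 150000 nM, and a further limit is quite possible.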

Compound 4, half-maximal inhibitory concentration: 43400 nM
For compound 4 the middle estimate is 1.2-fold (0.06 log units) above the measured one, and the stated range covers the measured number.
By their numbers in this assay, from the lowest: compound 3; then compound 2; then compound 4. At a limit, above all of these: compound 1.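

With the group on the carbonyl carbon held fixed, pyrrolidin-1-yl in place of dimethylamino on the aromatic carbon next to the ring nitrogen gives a number in this assay, and the result is an at least 1.1-fold lower number from compound 1 to compound 4 (0.06 log units; that floor lies within the scatter). Going by these compounds alone, this is the first read at this position, as the earlier step concerned only the group on the carbonyl carbon. The true size of the change stays unknown because compound 1 stands at a limit: the limit of > 50000 nM in this assay, at which 1 of the 4 values shown sits.

Going by these compounds, it remains open how a morpholine ring or a primary amine at this position would compare with pyrrolidin-1-yl when the group on the carbonyl carbon stays the same as in compound 4. Also open, on these data alone, is how the amine and the group on the carbonyl carbon combine, as compound 2 and compound 3 each differ from compound 4 in both places.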